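A few compounds are considered here, and "the series" means these few. Any claim that something is new, unique, unknown or untested is made for them only; others in the source may bear on it.

Three members of the series have been run in an ADME assay on CCRF-CEM cells (Homo sapiens) for cytotoxicity, with a stated time of 5 days; a higher number here means a weaker inhibitor, a lower number a stronger inhibitor. Compound 1 `[N-]=[N+]=N[C@H]1C[C@H](n2cnc3c(NCCCCCO)nc(N)nc32)O[C@@H]1CO` reaches only the limit of this assay, giving > 100000 nM. Compound 2 `COc1nc(N)c2ncn([C@H]3C[C@H](N=[N+]=[N-])[C@@H](CO)O3)c2n1` also stops at the limit in this assay, with > 100000 nM. Compound 3 `COc1nc(F)nc2c1ncn2[C@H]1C[C@H](N=[N+]=[N-])[C@@H](CO)O1` likewise returns only the limit, > 100000 nM. Compound 1 therefore cannot be placed above or below the other two, since (the limit of > 100000 nM in this assay, at which 3 of the 3 values shown sit). Compound 4 `CN(C)c1nc(N)nc2c1ncn2[C@H]1C[C@H](N=[N+]=[N-])[C@@H](CO)O1` shares the core of compound 1; the change is dimethylamino in place of (5-hydroxypentyl)amino on an aromatic carbon. For the measured compounds named here, no step between measured compounds is available to scale this change, and every value shown sits at the limit. The step is expected to be none beyond the scatter, so that a step that the limit leaves unreadable from compound 1 to compound 4 is the expectation. Compound 4 is estimated at 150000 nM, in the range 40000 nM to 500000 nM, with a limit again the likeliest outcome.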

Compound 4, half-maximal inhibitory concentration: > 100000 nM
Compound 4: a limit, no number; the forecaster's own chance of this, stated with the estimate: 85%; the middle value is on the limit's open side.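

No step can be read from compound 1 to compound 4, since both values are limits: the limit of > 100000 nM in this assay, at which 4 of the 4 values shown sit. The compounds shown leave open whether dimethylamino in place of (5-hydroxypentyl)amino makes any difference in this assay, where none yet gives a number.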